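The compounds below may be only part of what the source reports. "The series", "measured", "known", "first", "only" and "open" are said of these compounds alone.

The series shares one core, seen in compound 1 `O=C1CCC(=O)N1C[C@H]1CN(c2ccc(-n3cc(-c4ccccn4)cn3)c(F)c2)C(=O)O1` and compound 2 `O=C1O[C@@H](Cn2ccnc2)CN1c1ccc(-n2cc(-c3ccccn3)cn2)c(F)c1`. Among the measured compounds shown here, in an ADME assay on L02 cells (Homo sapiens) for cytotoxicity, read by MTT assay, with a stated time of 48 h (on this read-out lower numbers stand for stronger inhibition and higher numbers for weaker inhibition), compound 2 gives 350 ug/mL, the only number obtained in this set. For compound 1 this assay reports only the limit > 400 ug/mL, so compound 1 sits at the limit of > 400 ug/mL in this assay, at which 1 of the 2 values shown sits. For the measured compounds named here, the one measured step, an at least 1.1-fold lower number from compound 1 to compound 2 (0.05 log units; that floor lies within the scatter), therefore tells nothing that rises out of the scatter; it shows only that both compounds act weakly on these cells.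

Compound 3 `O=C1O[C@@H](CNC(=O)C(F)(F)F)CN1c1ccc(-n2cc(-c3ccccn3)cn2)c(F)c1` has not been measured. It differs from compound 2 by ((trifluoromethyl)carbonyl)amino in place of 1H-imidazol-1-yl on a saturated chain carbon bound to a saturated ring carbon. Going by the values given here, the only step that bears on this exchange is the one from compound 1 to compound 2 at the same place, and that step gives no direction and no size beyond the scatter. On that basis no move is expected in this assay: compound 3 is estimated at 350 ug/mL, between 150 ug/mL and 700 ug/mL. The step so expected from compound 2 to compound 3, no change at the digits printed from compound 2 to compound 3 (within the scatter), is estimated to lie within the scatter.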

Compound 3, half-maximal inhibitory concentration: > 400 ug/mL
Compound 3: no number, only a limit; the forecaster's own chance of this, stated with the estimate: 40%; middle value at least 1.1-fold (0.05 log units) away from the limit.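

In this assay compound 3 gives only a limit, > 400 ug/mL, and no number. The exchange at this place, ((trifluoromethyl)carbonyl)amino in place of 1H-imidazol-1-yl on a saturated chain carbon bound to a saturated ring carbon, gives an at least 1.1-fold higher number from compound 2 to compound 3 (0.05 log units; that floor lies within the scatter), so it adds no direction that rises out of the scatter, but it does show that a group with no ring and with one hydrogen-bond donor leaves the compound as weak on these cells as the two ring-bearing groups did. The step between compound 1 and compound 3 cannot be read, and compound 3 now stands with compound 1 at the same limit: the limit of > 400 ug/mL in this assay, at which 2 of the 3 values shown sit.

Going by these compounds, the actual values of compound 1 and compound 3 stay open, and with them the question of whether either truly differs from compound 2. Also open, on these data alone, is whether an amine, a carboxylic acid or a longer chain on this saturated chain carbon would move the number in this assay beyond the scatter.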